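The source may report more compounds than this note shows. Statements on the series, on what has been measured and on what is new or still open speak of the compounds shown alone.

Working notes on the series

Compound 1 `CN1C(=O)COc2cc(Nc3cc4c(cn3)ncn4CC3CC3)cnc21` and compound 3 `CN1C(=O)COc2cc(Nc3ncc4ncn(CC5CC5)c4n3)cnc21` share the cyclopropylmethyl-bearing side and the same cyclic amide side but carry different cores; the difference between the two cores is not broken down here. In an ADME assay on microsomes from liver (Rattus norvegicus) for metabolic stability (on this read-out lower numbers stand for a shorter-lived compound and higher numbers for a longer-lived compound), compound 1 gives > 1.66 h, which is a limit of the assay rather than a number. Compound 2 `Cc1nc(Nc2cnc3c(c2)OCC(=O)N3C)cc2c1ncn2CC1CC1` differs from compound 1 by methyl in place of hydrogen on an aromatic carbon. In this assay compound 2 gives > 1.66 h, again a limit. The step that the two limits leave unreadable from compound 1 to compound 2. For the measured compounds named here, compound 3 gives 0.3 h in this assay, the only number among the three; it alone sits away from the limit of > 1.66 h in this assay, at which 2 of the 3 values shown sit.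

Compound 4 `Cc1nc(Nc2cnc3c(c2)OCC(=O)N3C)nc2c1ncn2CC1CC1` stands to compound 3 as compound 2 stands to compound 1: methyl in place of hydrogen on an aromatic carbon. This is the same kind of change, not the same one, since here the carbon lies in a six-membered aromatic ring with 2 nitrogen and is opposite the ring nitrogen, whereas in compound 2 the ring holds 1 nitrogen.

Since the step from compound 1 to compound 2 gives no readable size, a small step is expected, a 1.3-fold higher number from compound 3 to compound 4 (0.12 log units; within the scatter), resting on compound 3 at 0.3 h. Compound 4 is therefore estimated at 0.4 h in this assay, expected between 0.15 h and 1.2 h.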

Compound 4, half-life: 0.917 h
Compound 4: the middle estimate sits 2.3-fold (0.36 log units) below what was measured; the measured number falls inside the stated range.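

In this assay methyl in place of hydrogen on an aromatic carbon of the six-membered aromatic ring with 2 nitrogen gives a 3.1-fold higher number from compound 3 to compound 4 (0.49 log units; beyond the scatter) and so, on this one core, the change goes with a longer half-life. The same kind of change on the core of compound 1 cannot be read, because compound 1 and compound 2 both give a limit of the assay rather than a number: the limit of > 1.66 h in this assay, at which 2 of the 4 values shown sit. Whether the change carries from one core to another is therefore not shown, in size or in direction, and a single readable step makes no pattern.

The compounds shown leave open whether another group on the same aromatic carbon, such as ethyl, methoxy or an amine, would shift the half-life as methyl does on the core of compound 3. Also open, from the compounds shown here alone, is whether this step would hold with a group other than cyclopropylmethyl on the core, for example a longer chain.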